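The source may hold more compounds than are shown below. What is called first, only, known or untested is meant among the compounds shown, and "the series" means these compounds.

In an ADME assay on MT4 cells (Homo sapiens) for cytotoxicity, read by MTT assay, with a stated time of 5 days (a higher number here means that more compound is tolerated, a lower number that less compound is tolerated), compound 1 `Cc1cc(C#N)cc(C)c1Oc1nc(NCCn2ccc(=O)[nH]c2=O)ncc1Cl` reports only a limit, > 11600 nM. Among the compounds with values here, compound 2 `Cc1cc(C)c(Oc2nc(NCCn3ccc(=O)[nH]c3=O)ncc2Cl)c(C)c1` gives 2490 nM, the only actual number so far. Compound 3 `Cc1cc(C)c(Oc2ccnc(NCCn3ccc(=O)[nH]c3=O)n2)c(C)c1` differs from it by hydrogen in place of chloro on an aromatic carbon. Within the data shown here, the one measured step, an at least 4.6-fold lower number from compound 1 to compound 2 (0.66 log units; beyond the scatter), lies beyond the scatter but concerns cyano and methyl, not chloro, so it is only a loose guide to size and none to direction. A modest change toward more compound tolerated is expected, a 2.0-fold higher number from compound 2 to compound 3 (0.30 log units; within the scatter). For compound 3 the estimated value is 5000 nM, with an expected range of 1800 nM to 14000 nM.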

Compound 3, half-maximal cytotoxic concentration: 272000 nM
Beside the measured number, compound 3's estimate is 54-fold (1.74 log units) below it; measured number outside the range, above it.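

In this assay, this aromatic carbon, ortho to a large group and two atoms from the ring nitrogen, proves highly sensitive: hydrogen in place of chloro gives a 110-fold higher number from compound 2 to compound 3 (2.04 log units; beyond the scatter). The change involves a single heavy atom, with no hydrogen-bond donor, acceptor or net charge entering or leaving. Nothing shown here gives a cause for the step.

The compounds shown leave open whether fluoro, methyl or an amine on this carbon would read nearer compound 2 or compound 3. On these data alone, whether the step carries over when cyano replaces methyl also remains open.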